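This account rests on a few compounds, and the source may have more. Where it says the series, first, only, none or still open, it means among the compounds named here.

Measured in an ADME assay on a cell-free system (plasma, Mus musculus) for metabolic stability, read by LC-MS, tested at 2 uM; on this read-out higher numbers stand for a longer-lived compound and lower numbers for a shorter-lived compound:
- compound 1 `CC(C)N1CCC(c2ccc3c(c2)oc(=O)n3C(=O)NCCCCc2ccccc2)CC1`: 0.667 h
- compound 2 `CN1CCC(c2ccc3c(c2)oc(=O)n3C(=O)NCCCCc2ccccc2)CC1=O`: 0.6 h
- compound 3 `CN1CCN(c2ccc3c(c2)oc(=O)n3C(=O)NCCCCc2ccccc2)CC1`: < 0.0834 h

Compound 3 is known only through a limit of the assay, < 0.0834 h, and not through a number. Both measured steps into it lie beyond the scatter: an at least 7.9-fold lower number from compound 1 to compound 3 (0.90 log units; beyond the scatter) and an at least 7.1-fold lower number from compound 2 to compound 3 (0.85 log units; beyond the scatter). Each brings in 4-methylpiperazin-1-yl on an aromatic carbon. The exchange between the other two groups gave a 1.1-fold lower number from compound 1 to compound 2 (0.05 log units; within the scatter).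

Compound 4 `CCN1CCN(c2ccc3c(c2)oc(=O)n3C(=O)NCCCCc2ccccc2)CC1` differs from compound 3 in one place: methyl in place of hydrogen on a saturated chain carbon bound to an amine nitrogen in a ring, turning 4-methylpiperazin-1-yl into 4-ethylpiperazin-1-yl. Within the data shown here, no measured step covers this change directly. The large steps replace the whole group, whereas compound 4 stays close to compound 3, so the expectation in this assay is no step beyond the scatter, in either direction. The expected step is a step that the limit leaves unreadable from compound 3 to compound 4. The estimate for compound 4 is 0.08 h, with an expected range from 0.04 h to 0.2 h. A report as a limit again would fit this expectation.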

Compound 4, half-life: < 0.0834 h
Compound 4 gave a limit, no number (the forecaster's own chance of this, stated with the estimate: 65%); the middle value lies beyond the limit too.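

In this assay the change from 4-methylpiperazin-1-yl to 4-ethylpiperazin-1-yl leaves compound 4 at the same limit as compound 3, so the step between them cannot be read: the limit of < 0.0834 h in this assay, at which 2 of the 4 values shown sit.

Methyl in place of hydrogen on this saturated chain carbon does not bring the piperazine compound up to a readable half-life, and the gap to the two piperidine compounds remains, with an at least 7.1-fold lower number from compound 2 to compound 4 (0.85 log units; beyond the scatter) and an at least 7.9-fold lower number from compound 1 to compound 4 (0.90 log units; beyond the scatter). The short half-life, until now seen with the single 4-methylpiperazin-1-yl compound, therefore also holds for 4-ethylpiperazin-1-yl, and among the compounds shown both readable values belong to compound 1 and compound 2.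

On these data alone, how far compound 3 and compound 4 lie past the limit stays unknown, so whether the added methyl shifts the half-life in either direction remains open. Among these compounds, also open is whether a larger group on the same ring nitrogen, such as isopropyl as in 4-isopropylpiperazin-1-yl, or a ring carbonyl on the piperazine like the one in compound 2, would give a readable number in this assay.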